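Solubility notes: from compound 1 to compound 4

The source may hold more compounds than are shown below. What is called first, only, known or untested is meant among the compounds shown, and "the series" means these compounds.

Measured so far:
compound 1 `CNC(=O)c1cc(C(=O)NC)c(=O)n(Cc2ccccc2)c1` — >= 118 ug/mL
compound 2 `CNC(=O)c1cc(C(=O)NC2CC2)cn(Cc2cccc3[nH]c(C)nc23)c1=O` — >= 198 ug/mL
compound 3 `CNC(=O)c1cc(C(=O)NC2CC2)cn(CC2CCCOC2)c1=O` — >= 131 ug/mL

In a physicochemical assay for solubility (a lower number here means a less soluble compound, a higher number a more soluble compound), compound 1 gives >= 118 ug/mL, which is a limit of the assay and not a number. Compound 2 gives >= 198 ug/mL, also a limit. Compound 3 gives >= 131 ug/mL, again a limit. Among the compounds with values here, compound 1 therefore stands at the limit of >= 118 ug/mL in this assay, at which 1 of the 3 values shown sits, with the other two compounds at the limit of >= 131 ug/mL in this assay, at which 1 of the 3 values shown sits, and (the limit of >= 198 ug/mL in this assay, at which 1 of the 3 values shown sits); none of the three is pinned to a number, and no step between measured compounds can be read from them.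

Compound 4 `CNC(=O)c1cc(C(=O)NCCOC)cn(Cc2ccccc2)c1=O` is the next compound, not yet measured. It differs from compound 1 in one place: methoxymethyl in place of hydrogen on a saturated chain carbon bound to an amide-type nitrogen. Going by these compounds, with every measured value a limit, the size of any step is unknown. The step from compound 1 to compound 4 in this assay is expected to be none beyond the scatter or, if anything, upward, a step that the limit leaves unreadable from compound 1 to compound 4. Compound 4 is expected to give about 160 ug/mL, within a range of 60 ug/mL to 450 ug/mL, and it is expected that the assay again reports only a limit for compound 4.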

Compound 4, solubility: >= 164 ug/mL
Compound 4: only a limit was reported; the forecaster's own chance of this, stated with the estimate: 70%; middle value at least 1.0-fold (0.01 log units) from the limit.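

In this assay compound 4 gives >= 164 ug/mL, which is a limit of the assay and not a number. Within the data shown here, compound 1 also stands only at a limit, so no step from compound 1 to compound 4 can be read. The compounds shown leave open whether methylcarbamoyl to (2-methoxyethyl)carbamoyl changes the read-out at all.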